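The source may report more compounds than this note shows. Statements on the series, on what has been measured and on what is new or still open speak of the compounds shown alone.

In a functional assay on HL-60 cells (Homo sapiens) for cytotoxicity, read by MTT assay, with a stated time of 4 days (a lower number here means a stronger inhibitor, a higher number a weaker inhibitor), compound 1 `C=C1C[C@]23C[C@@]1(O)CC[C@H]2c1ccc(O)c(C)c1[C@@H]3Cn1cc(-c2ccccn2)nn1` gives only a limit, > 20000 nM. Two related compounds, which differ from compound 1 in the shared core, give numbers: compound 2 `C=C1C(=O)[C@]23C[C@@]1(O)CC[C@H]2c1ccc(OS(=O)(=O)c2ccc(C)cc2)c(C)c1[C@@H]3Cn1cc(-c2ccccn2)nn1` gives 1810 nM, and compound 3 `C=C1C(=O)[C@]23C[C@@]1(O)CC[C@H]2c1ccc(OS(=O)(=O)c2ccc(C)cc2)c(C)c1[C@@H]3Cn1cc(-c2ccc(Br)cc2)nn1` gives 1020 nM. The step of a 1.8-fold lower number from compound 2 to compound 3 (0.25 log units; within the scatter) is the same exchange of groups and stays within the scatter of repeated measurements.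

Compound 4 `C=C1C[C@]23C[C@@]1(O)CC[C@H]2c1ccc(O)c(C)c1[C@@H]3Cn1cc(-c2ccc(Br)cc2)nn1` has not yet been measured. It differs from compound 1 by 4-bromophenyl in place of pyridin-2-yl on an aromatic carbon. Within the data shown here, the one measured step that bears on this change, a 1.8-fold lower number from compound 2 to compound 3 (0.25 log units; within the scatter), is within the scatter, so in this assay no shift beyond the scatter is expected from the exchange. Compound 1 stands at the upper limit of what the assay reports, because it sits at the limit of > 20000 nM in this assay, at which 1 of the 3 values shown sits, and compound 4 is therefore expected to sit at or beyond that limit as well. For compound 4 the estimated value is 30000 nM, with a range from 8000 nM to 100000 nM. The expected step for compound 4 is a step that the limit leaves unreadable from compound 1 to compound 4.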

Compound 4, half-maximal inhibitory concentration: > 20000 nM
Compound 4 ended at the assay's limit; the forecaster's own chance of this, stated with the estimate: 70%; the middle value does not contradict the limit.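

Among these compounds, compound 4 gives > 20000 nM, which is a limit of the assay and not a number, just as compound 1 does, so no step between the two can be read. The compounds shown leave open how far either compound lies beyond that limit, and whether 4-bromophenyl in place of pyridin-2-yl changes anything on this core.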